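The compounds below may be only part of what the source reports. "The series", "measured", "known", "first", "only" and "open" are said of these compounds alone.

Compound 1 `O=c1cc(N2CCNCC2)c2c(OCc3ccccc3)cccc2o1` gives 429000 nM
Compound 2 `CCCOc1ccc2c(N3CCNCC3)cc(=O)oc2c1C` gives 7770 nM

Both numbers come from a functional assay on a cell-free system (plasma, Homo sapiens) for inhibition, with Plasma (Rattus norvegicus) as the target (on this read-out higher numbers stand for weaker inhibition and lower numbers for stronger inhibition), and are all that has been measured so far. Compound 2 holds the lower of the two numbers, and with 7770 nM against compound 1 at 429000 nM the gap lies beyond the scatter of repeated measurements. These two compounds differ in more than one place, so their gap cannot be tied to any single change.

Compound 3 `Cc1c(OCCOc2ccccc2)ccc2c(N3CCNCC3)cc(=O)oc12` differs from compound 2 in one place: phenoxy in place of methyl on a saturated chain carbon, two bonds along the chain from an oxygen on an aromatic ring. The change is counted as phenoxy in place of methyl on a saturated chain carbon, two bonds along the chain from an oxygen on an aromatic ring and can also be read as propyl to 2-phenoxyethyl.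

Among the measured compounds shown here, no measured pair shows this change alone, so any expectation in this assay is loose, and a move in either direction is possible. The expected 1.3-fold lower number from compound 2 to compound 3 (0.11 log units; within the scatter) is small and leans towards a lower number without going beyond the scatter. Compound 3 is estimated at 6000 nM with an expected range from 1200 nM to 30000 nM for its measurement.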

Compound 3, half-maximal inhibitory concentration: 14300 nM
The estimate for compound 3 lay 2.4-fold (0.38 log units) below the measured number, and the stated range covers the measured number.
By their numbers in this assay, from the lowest: compounds 2 and 3 (each within the scatter of the next); then compound 1.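

In this assay, replacing the propyl chain with 2-phenoxyethyl gives a 1.8-fold higher number from compound 2 to compound 3 (0.26 log units; within the scatter), so on this read-out compound 2 and compound 3 cannot be told apart. Among the compounds shown here, this is the first sign that this position can carry far more than a simple alkyl chain: the phenoxy group that enters has 7 heavy atoms and an aromatic ring, the methyl that leaves has 1 heavy atom, and the number still stays within the scatter. No measurement available here bears on why the number stays within the scatter.

This is a single step on a single chain, so it cannot show whether the same swap would behave alike on the core of another compound, or whether any added group at this place would do the same. Also open, on these data alone, is what happens when the phenoxy is replaced by an amine such as dimethylamino or by a carboxylic acid, or when a longer chain places the phenoxy further from the oxygen on the aromatic ring.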